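The source may hold more compounds than are shown below. What is called first, only, known or untested is meant among the compounds shown, and "the series" means these compounds.

Of the compounds shown here, three sharing one core have been tested so far, and they differ only in the group on a saturated chain carbon bound to a nitrogen on an aromatic ring. In an ADME assay on A549 cells (Homo sapiens) for cytotoxicity, read by resazurin assay, with a stated time of 48 h (a lower number here means that less compound is tolerated, a higher number that more compound is tolerated), compound 1 `CC(C)CNc1ccc(NC(=O)c2cc(Cl)ccc2O)c(Cl)c1` gives (60000 nM), compound 2 `O=C(Nc1ccc(NCC2CC2)cc1Cl)c1cc(Cl)ccc1O` gives (14400 nM) and compound 3 `O=C(Nc1ccc(NCc2ccc(C(F)(F)F)cc2)cc1Cl)c1cc(Cl)ccc1O` gives (62700 nM). Compound 3 stands level with compound 1, the measured step being (a 1.0-fold higher number from compound 1 to compound 3 (0.02 log units; within the scatter)). It stands clear of compound 2, with a modest step of (a 4.4-fold higher number from compound 2 to compound 3 (0.64 log units; beyond the scatter)), and that gap mirrors the earlier one of (a 4.2-fold lower number from compound 1 to compound 2 (0.62 log units; beyond the scatter)).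

The next compound, compound 4 `O=C(Nc1ccc(NCc2cccc(C(F)(F)F)c2)cc1Cl)c1cc(Cl)ccc1O`, has the same atoms joined differently: 3-(trifluoromethyl)phenyl in place of 4-(trifluoromethyl)phenyl (3-(trifluoromethyl)phenyl in place of 4-(trifluoromethyl)phenyl on a saturated chain carbon bound to a nitrogen on an aromatic ring). For the measured compounds named here, no measured step moves a group around a ring, so the evidence here is only indirect. Replacing isopropyl with the much larger 4-(trifluoromethyl)phenyl left the number unchanged within the scatter, and only compound 2 departs from that level, and modestly. In this assay no change beyond the scatter is therefore expected, and the estimated step is (a 1.3-fold lower number from compound 3 to compound 4 (0.10 log units; within the scatter)). For compound 4 the expected value is (50000 nM), with an estimated range of (20000 nM to 110000 nM).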

Compound 4, half-maximal cytotoxic concentration: 13300 nM
For compound 4 the middle estimate is 3.8-fold (0.58 log units) above the measured one, outside the stated range (below it).
By their numbers in this assay, from the lowest: compounds 4 and 2 (each within the scatter of the next); then compounds 1 and 3 (each within the scatter of the next).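

In this assay, replacing 4-(trifluoromethyl)phenyl with 3-(trifluoromethyl)phenyl gives a modest step (a 4.7-fold lower number from compound 3 to compound 4 (0.67 log units; beyond the scatter)), even though the two groups hold the same atoms and the same counts, so at this place the way a group's atoms are joined can matter as much as which atoms it contains. The other two comparisons show that the four compounds fall into two levels that do not follow the atom count of the group: 3-(trifluoromethyl)phenyl stands level with cyclopropyl (a 1.1-fold lower number from compound 2 to compound 4 (0.03 log units; within the scatter)) and clear of isopropyl (a 4.5-fold lower number from compound 1 to compound 4 (0.65 log units; beyond the scatter)), while 4-(trifluoromethyl)phenyl, with the same atom count, stands level with isopropyl. Nothing measured here accounts for why the two isomers differ.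

Going by these compounds, it remains open whether 2-(trifluoromethyl)phenyl would stand with compound 3, with compound 4 or elsewhere, and whether an unsubstituted phenyl would reach either level. It is also unknown whether a 3-chlorophenyl or 4-chlorophenyl pair would split in the same way, which would show whether this difference is particular to the trifluoromethyl group.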